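The source may hold more compounds than are shown below. What is called first, only, known or untested is meant among the compounds shown, and "the series" means these compounds.

Compound 3 `CN(C)CCNc1nc(-c2ccc(NC(=O)Nc3ccc(F)cc3)cc2)nc2ccsc12` gives 350 nM in a functional assay on HT-29 cells (Homo sapiens) for cytotoxicity, read by MTT assay, with a stated time of 72 h; on this read-out lower numbers stand for stronger inhibition and higher numbers for weaker inhibition. For comparison, compound 1 `CN(C)CCCNc1nc(-c2ccc(NC(=O)Nc3ccc(Cl)cc3)cc2)nc2c(Cl)c(Cl)sc12` gives 330 nM and compound 2 `CN(C)CCCNc1nc(-c2ccc(NC(=O)Nc3ccc(Cl)cc3Cl)cc2)nc2c(Cl)c(Cl)sc12` gives 1320 nM, so compound 3 lies within the scatter of compound 1 and clearly below compound 2. Compound 4 `CN(C)CCNc1nc(-c2ccc(NC(=O)Nc3ccccc3Cl)cc2)nc2ccsc12` differs from compound 3 by 2-chlorophenyl in place of 4-fluorophenyl on an amide-type nitrogen. Among the measured compounds shown here, the only measured step that changes a halogen on this outer ring is a 4.0-fold higher number from compound 1 to compound 2 (0.60 log units; beyond the scatter), which adds a chloro rather than exchanging one for a fluoro, so it bears on the present change only loosely. A weakening of similar or somewhat smaller size is expected, a 1.9-fold higher number from compound 3 to compound 4 (0.27 log units; within the scatter). Compound 4 is therefore estimated at 650 nM, with a range from 250 nM to 1700 nM.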

Compound 4, half-maximal inhibitory concentration: 310 nM
Compound 4: the middle estimate sits 2.1-fold (0.32 log units) above what was measured; measured number inside the range.
By their numbers in this assay, from the lowest: compounds 4, 1 and 3 (each within the scatter of the next); then compound 2.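

In this assay the exchange of 4-fluorophenyl for 2-chlorophenyl on the amide-type nitrogen gives a 1.1-fold lower number from compound 3 to compound 4 (0.05 log units; within the scatter) and so leaves no change that can be told from the scatter. The earlier step of a 4.0-fold higher number from compound 1 to compound 2 (0.60 log units; beyond the scatter) added a chloro to a ring already carrying one, and that loss of strength does not appear with this exchange. Nothing measured here explains the difference between the two steps.

Open, as far as these compounds go, is how plain phenyl, with no halogen, or a pyridine ring would read on this nitrogen.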